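The source may report more compounds than this note shows. Statements on the series, on what has been measured and on what is new or still open speak of the compounds shown alone.

Measured so far:
compound 1 `Cc1ccc2c(Cn3cc(CNc4ccc(-c5nc6ccc(C)cc6s5)cc4)nn3)cc(=O)oc2c1`: 46200 nM
compound 2 `Cn1c(-c2cn(Cc3cc(=O)oc4cc(O)ccc34)nn2)nc2ccccc21`: > 100000 nM

In a functional assay on A549 cells (Homo sapiens) for inhibition, read by MTT assay, with a stated time of 72 h (a lower number here means a stronger inhibitor, a higher number a weaker inhibitor), compound 1 gives 46200 nM. Compound 2 gives > 100000 nM in this assay, which is a limit of the assay and not a number. Among the measured compounds shown here, compound 2 thus stands at the weak end of the two values shown, known only as a limit, as the limit of > 100000 nM in this assay, at which 1 of the 2 values shown sits, records; compound 1 is the one with a numeric reading.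

The step to compound 3 `Cc1ccc2c(Cn3cc(-c4nc5ccccc5n4C)nn3)cc(=O)oc2c1` is methyl in place of hydroxy on an aromatic carbon. For the measured compounds named here, no measured pair separates these two structures, so the size of the step rests on expectation alone. No change beyond the usual scatter of this assay is expected, and with compound 2 known only as a limit the direction cannot be set from the data. Compound 3 is expected around 100000 nM, within 40000 nM to 300000 nM. The expected step is a number no higher from compound 2 to compound 3 (the limit leaves the size open), with a fair chance that compound 3 again returns only a limit.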

Compound 3, half-maximal inhibitory concentration: 16900 nM
Compound 3: the middle estimate sits 5.9-fold (0.77 log units) above what was measured, and the stated range ends above it.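

In this assay, this aromatic carbon of the shared core proves sensitive to substitution: methyl in place of hydroxy gives an at least 5.9-fold lower number from compound 2 to compound 3 (0.77 log units; beyond the scatter), and compound 3 gives a numeric reading of 16900 nM. Compound 2 gives > 100000 nM, which is a limit of the assay and not a number. The size of the step therefore remains a lower bound because compound 2 is known only as a limit: the limit of > 100000 nM in this assay, at which 1 of the 3 values shown sits.

The shown pair cannot tell whether the step reflects the presence of methyl or the loss of hydroxy, and a methoxy group or an amine on this aromatic carbon would help separate the two readings. Going by these compounds, whether the same change carries the same size on the core of compound 1 also remains open.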